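The source may hold more compounds than are shown below. What is called first, only, known or untested is meant among the compounds shown, and "the series" means these compounds.

Compounds measured so far:
- compound 1 `O=C(Nc1nc(-c2ccccn2)cs1)c1ccccc1O`: "not determined" (no result reported) in an ADME assay on Vero cells (Chlorocebus sabaeus) for cytotoxicity, read by MTT assay, with a stated time of 72 h; a higher number here means that more compound is needed for the effect, a lower number that less compound is needed
- compound 2 `CC(=O)c1cccc(C(=O)Nc2nc(-c3ccccn3)cs2)c1`: 1500 nM

The two compounds share a core to which an amide is attached, and they differ only in the ring carried by the carbonyl of that amide. On these data alone, compound 1 stands without a number in this assay, so its own toxicity toward the cells is unknown. For the measured compounds named here, compound 2, the one measured compound, gives 1500 nM in this assay, which places it in a range where the cells are affected at fairly low concentrations.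

The next compound, compound 3 `O=C(Nc1nc(-c2ccccn2)cs1)c1ccccn1`, keeps the core and the amide of compound 1 and changes the ring on the carbonyl: pyridin-2-yl in place of 2-hydroxyphenyl on a carbonyl carbon. Going by the values given here, since compound 1 has no value, no step can be computed for this change, and the one number available, that of compound 2, is the only anchor. With a single anchor, no direction for the step in this assay can be claimed; a shift beyond the scatter in either direction is possible but not supported by anything shown.

On this basis compound 3 is expected to give about 2500 nM in this assay, with a range estimated from 600 nM to 12000 nM.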

Compound 3, half-maximal effective concentration: 5400 nM
For compound 3 the middle estimate is 2.2-fold (0.33 log units) below the measured one; low and high end bracket the measured number.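

For the compounds shown here, compound 1 carries no number in this assay, so no step from compound 1 to compound 3 can be read. The compounds shown leave open how replacing 2-hydroxyphenyl with pyridin-2-yl on the carbonyl carbon shifts the value in this test. No available evidence bears on the result for compound 3.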